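Cytotoxicity notes on a small amide series

The source may report more compounds than this note shows. Statements on the series, on what has been measured and on what is new or still open speak of the compounds shown alone.

Compound 1 `COc1ccc2nc(C)cc(OCCNc3cc(C)cc(C)c3)c2c1`: in a toxicity assay on HepG2 cells (Homo sapiens) for inhibition, read by CellTiter-Glo, with a stated time of 48 h (on this read-out lower numbers stand for stronger inhibition and higher numbers for weaker inhibition), compound 1 gives 31600 nM.
Compound 2 `COc1ccc(NC(=O)COc2cc(C)nc3ccc(OC)cc23)cc1`: in this assay compound 2 gives only a limit, > 100000 nM.

Compound 2 thus stands at the limit of > 100000 nM in this assay, at which 1 of the 2 values shown sits, with no number of its own. Compound 3 `COc1ccc2nc(C)cc(OCC(=O)Nc3ccncc3)c2c1` carries pyridin-4-yl in place of 4-methoxyphenyl on an amide-type nitrogen. Going by the values given here, no measured pair differs in a single place, so the size of such a step is untested here. Starting from a limit, the expected step in this assay is none beyond the scatter, in no set direction. Compound 3 is expected at 100000 nM, ranging 30000 nM to 300000 nM. The step of a number no higher from compound 2 to compound 3 (the limit leaves the size open) is expected to be small.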

Compound 3, half-maximal inhibitory concentration: > 100000 nM
Compound 3: a limit, no number; the forecaster's own chance of this, stated with the estimate: 60%; the middle value lies on the limit itself.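

Compound 2 and compound 3 each give only a limit in this assay, so no step can be read between them: the limit of > 100000 nM in this assay, at which 2 of the 3 values shown sit.

From the compounds shown here alone, whether pyridin-4-yl in place of 4-methoxyphenyl on an amide-type nitrogen changes inhibition at all stays open.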